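A few compounds are considered here, and "the series" means these few. Any claim that something is new, unique, unknown or untested is made for them only; others in the source may bear on it.

In an assay on isolated protein for inhibition of alpha-galactosidase (Coffea arabica), read by spectrophotometry, tested at 1000 uM (a higher number here means more inhibition at the concentration tested (going by the name of the read-out), a lower number less inhibition), compound 1 `O[C@@H]1[C@@H](O)CN[C@H]1c1ccc(-c2ccccc2)cc1` gives 0.3%. Compound 2 `O[C@@H]1[C@@H](O)CN[C@H]1c1ccc(F)cc1` differs from compound 1 by fluoro in place of phenyl on an aromatic carbon. In this assay compound 2 gives 16.6%, and the step is a number 16.3 percentage points higher from compound 1 to compound 2 (beyond the scatter). Compound 3 `O[C@H]1[C@H](O)CN[C@@H]1c1ccc(-c2ccccc2)cc1` is related to compound 1 by the two compounds have the same atoms and bonds and differ only in configuration as drawn: 3 of 3 stereo elements differ (all stereocentres are inverted: mirror images); a stereocentre at a saturated ring carbon is drawn S in compound 1 and R in compound 3; a stereocentre at a saturated ring carbon is drawn S in compound 1 and R in compound 3; a stereocentre at a saturated ring carbon is drawn S in compound 1 and R in compound 3. In this assay compound 3 gives 0%; the step is a number 0.3 percentage points lower from compound 1 to compound 3 (within the scatter), and the two compounds share (the fact that compounds 1 and 3 differ only in the configuration as drawn).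

Compound 4 `O[C@H]1[C@H](O)CN[C@@H]1c1ccc(F)cc1` has not yet been measured in this assay. It differs from compound 3 by fluoro in place of phenyl on an aromatic carbon, the same change that separates compound 2 from compound 1, at the same place in the ring; the two cores differ by the two compounds have the same atoms and bonds and differ only in configuration as drawn: 3 of 3 stereo elements differ (all stereocentres are inverted: mirror images); a stereocentre at a saturated ring carbon is drawn S in compound 1 and R in compound 3; a stereocentre at a saturated ring carbon is drawn S in compound 1 and R in compound 3; a stereocentre at a saturated ring carbon is drawn S in compound 1 and R in compound 3.

The earlier step, a number 16.3 percentage points higher from compound 1 to compound 2 (beyond the scatter), rose from compound 1, which gave 0.3%. Compound 3 starts from 0%, and the same change is expected to give a number 8 percentage points higher from compound 3 to compound 4 (within the scatter), although the mirror-image core gives no measured guide to how far it will follow compound 2. Compound 4 is therefore estimated at 8% in this assay, between 0% and 22%.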

Compound 4, a percentage reported as inhibition, at one concentration (the size of the read-out at that concentration, not a potency): 2%
The estimate for compound 4 lay 6 percentage points above the measured number; low and high end bracket the measured number.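

On the core of compound 3, the change from phenyl to fluoro gave, in this assay, a number 2 percentage points higher from compound 3 to compound 4 (within the scatter), so it did not carry over in size from the core of compound 1: the same change on two cores in this assay, a number 16.3 percentage points higher (beyond the scatter) from compound 1 to compound 2 and a number 2 percentage points higher (within the scatter) from compound 3 to compound 4, 14.3 percentage points apart, beyond the scatter of two such steps

Inverting all the stereocentres of the fluoro compound gave a number 14.6 percentage points lower from compound 2 to compound 4 (beyond the scatter), whereas the same inversion of the phenyl compounds made no difference beyond the scatter, so the rise seen with fluoro appears in only one of the two mirror-image forms: the fact that compounds 2 and 4 differ only in the configuration as drawn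

This rests on a single pair of cores and a single replacement, so it does not show which of the inverted stereocentres matters, why the two cores differ, or how the change would behave on any other core.

The compounds shown leave open whether chloro, methoxy or an amine in place of the phenyl would follow the same split between the two cores. They also leave open what a core with only one stereocentre inverted would give with phenyl or fluoro.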